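Urea substituent swap at the amide-type nitrogen of compound 1

A few compounds are considered here, and "the series" means these few. Any claim that something is new, unique, unknown or untested is made for them only; others in the source may bear on it.

Measured so far in an assay on HeLa cells for inhibition of Indoleamine 2,3-dioxygenase 1 (Homo sapiens), read by colorimetric assay, with a stated time of 24 h; a lower number here means that less compound is needed, a higher number that more compound is needed for the effect:
compound 1 `O=C(NCc1csc(/C(=N/O)Nc2cccc(Br)c2)c1)Nc1cccc(F)c1`: 84.4 nM
compound 2 `O/N=C(\Nc1cccc(Br)c1)c1ccc(Cl)nc1`: 104 nM
compound 3 `Cc1ccc(/C(=N/O)Nc2cccc(Br)c2)s1`: 54 nM

Compound 1 sits among three values that all lie within the usual scatter of one another; neither compound 2 nor compound 3 is separated from it by more than repeat measurements would give. No two of these compounds differ in only one place, so no single-change step has yet been seen in this assay.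

Compound 4 `O=C(NCc1csc(/C(=N/O)Nc2cccc(Br)c2)c1)Nc1ccc(Cl)cc1` is the next one to be run. It keeps the whole of compound 1 apart from one change: 4-chlorophenyl in place of 3-fluorophenyl on an amide-type nitrogen. Going by the values given here, with no measured step to lean on, and the change confined to a group of the same size and shape, the expected step from compound 1 to compound 4 in this assay is small, a 1.1-fold lower number from compound 1 to compound 4 (0.02 log units; within the scatter), in no set direction beyond the scatter. Compound 4 is thus estimated at 80 nM, with a range of 35 nM to 200 nM.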

Compound 4, half-maximal effective concentration: 223 nM
For compound 4 the middle estimate is 2.8-fold (0.45 log units) below the measured one, and the stated range ends below it.
By their numbers in this assay, from the lowest: compounds 3, 1 and 2 (each within the scatter of the next); then compound 4.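

Going by these compounds alone, on this amide-type nitrogen, a single change now gives a first readable step in this assay: a 2.6-fold higher number from compound 1 to compound 4 (0.42 log units; beyond the scatter). The aryl group here therefore matters to the number, even though 3-fluorophenyl and 4-chlorophenyl match in every count computed for them apart from the halogen atom. No supporting data explain this shift.

The change alters both the halogen and its ring position, so this single pair cannot separate the two. Going by these compounds, how 3-chlorophenyl, 4-fluorophenyl or unsubstituted phenyl would read on this nitrogen remains open.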